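The source may report more compounds than this note shows. Statements on the series, on what has been measured and on what is new or still open speak of the compounds shown alone.

Measured so far in a functional assay on PC-3 cells (Homo sapiens) for cytotoxicity, read by MTT assay, with a stated time of 48 h; on this read-out higher numbers stand for weaker inhibition and lower numbers for stronger inhibition. Compound 1 `OC[C@@H]1C[C@H](CO)[C@@H]2C(c3ccc(Cl)cc3)=NO[C@H]12` gives > 50 ug/mL. Compound 2 `COc1ccc(C2=NO[C@@H]3[C@H](CO)C[C@H](CO)[C@H]23)cc1` gives > 50 ug/mL. Compound 3 `OC[C@@H]1C[C@H](CO)[C@@H]2C(c3ccc4ccccc4c3)=NO[C@H]12` gives 48.4 ug/mL.

The value of compound 1 is a limit of the assay, not a number. The value of compound 2 is likewise a limit. Only compound 3 returns a number, and it sits close to the limit of > 50 ug/mL in this assay, at which 2 of the 3 values shown sit. Within the data shown here, the one measured step, from compound 1 to compound 2, is a step that the two limits leave unreadable from compound 1 to compound 2; it concerns the same aromatic position as the change now followed.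

Compound 4 `Cc1ccc(C2=NO[C@@H]3[C@H](CO)C[C@H](CO)[C@H]23)cc1` differs from compound 1 by methyl in place of chloro on an aromatic carbon. Among the measured compounds shown here, with the sole comparable step unreadable and both values limits, nothing measured here marks a direction for this change. The step from compound 1 to compound 4 is therefore expected to be about a step that the limit leaves unreadable from compound 1 to compound 4. Compound 4 is estimated at 55 ug/mL, within 30 ug/mL to 120 ug/mL, most likely reported again as a limit.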

Compound 4, half-maximal inhibitory concentration: 28 ug/mL
For compound 4 the middle estimate is 2.0-fold (0.29 log units) above the measured one; measured number below the stated range.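

Methyl on this aromatic carbon gives the first readable steps at this position in this assay: an at least 1.7-fold lower number from compound 1 to compound 4 (0.25 log units; that floor lies within the scatter), and an at least 1.7-fold lower number from compound 2 to compound 4 (0.25 log units; that floor lies within the scatter). The step from chloro to methoxy still cannot be read. Each new step is a floor and not a size, because compound 1 and compound 2 each stand at a limit: the limit of > 50 ug/mL in this assay, at which 2 of the 4 values shown sit.

The compounds shown leave open how far the real gap extends beyond these floors. They also leave open whether an amine or a carboxylic acid at this position would move the number the same way.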